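A few compounds are considered here, and "the series" means these few. Any claim that something is new, unique, unknown or untested is made for them only; others in the source may bear on it.

Compound 1 `Cc1nc(N(C)C)nc(N[C@@H]2C[C@H](CO)[C@@H](O)[C@H]2O)c1-c1nc2ccccc2s1`: in an ADME assay on cells (Homo sapiens) for cytotoxicity, read by polymerase chain reaction, with a stated time of 3 days (on this read-out lower numbers stand for higher toxicity in this test and higher numbers for lower toxicity in this test), compound 1 gives 18000 nM.
Compound 2 `COCCNc1nc(C)c(-c2nc3ccccc3s2)c(N[C@@H]2C[C@H](CO)[C@@H](O)[C@H]2O)n1`: in this assay compound 2 gives 21000 nM.
Compound 3 `CCOCCNc1nc(C)c(-c2nc3ccccc3s2)c(N[C@@H]2C[C@H](CO)[C@@H](O)[C@H]2O)n1`: in this assay compound 3 gives 18000 nM.

All three compounds share the same core and differ only in the group on the aromatic nitrogen substituent. On the numbers shown, compound 3 sits level with compound 1, and together they carry the lowest numbers of the three; the step from compound 2 to compound 3 is a 1.2-fold lower number from compound 2 to compound 3 (0.07 log units; within the scatter), so none of the three is set apart from the others.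

Compound 4 `Cc1nc(NCCNS(C)(=O)=O)nc(N[C@@H]2C[C@H](CO)[C@@H](O)[C@H]2O)c1-c1nc2ccccc2s1` is not yet measured. It differs from compound 3 by methanesulfonamido in place of ethoxy on a saturated chain carbon, two bonds along the chain from a nitrogen on an aromatic ring.

Among the compounds with values here, two measured steps touch the same position: no change at the digits printed from compound 1 to compound 3 (within the scatter) and a 1.2-fold lower number from compound 2 to compound 3 (0.07 log units; within the scatter). Both swaps at that position left the read-out of this assay unchanged beyond the scatter, although neither brings in a sulfur-containing group, so the new change is larger than any tried so far. Within the data shown here, with no measured example pointing in either direction, compound 4 is expected to show no change at the digits printed from compound 3 to compound 4 (within the scatter), that is, no step beyond the scatter. The estimate for compound 4 in this assay is therefore 18000 nM, within a range from 8000 nM to 40000 nM.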

Compound 4, half-maximal cytotoxic concentration: > 25000 nM
Compound 4: no number, only a limit; the forecaster's own chance of this, stated with the estimate: 10%; middle value at least 1.3-fold (0.14 log units) away from the limit.
By their numbers in this assay, from the lowest: compounds 1, 3 and 2 (each within the scatter of the next). At a limit, above all of these: compound 4.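

Compound 4 puts a sulfur-containing group on a saturated chain carbon, two bonds along the chain from a nitrogen on an aromatic ring, and in this assay compound 4 gives > 25000 nM, which is a limit and not a number. Set against the other three compounds, the result reads as an at least 1.3-fold higher number from compound 3 to compound 4 (0.14 log units; that floor lies within the scatter), an at least 1.1-fold higher number from compound 2 to compound 4 (0.07 log units; that floor lies within the scatter) and an at least 1.3-fold higher number from compound 1 to compound 4 (0.14 log units; that floor lies within the scatter). The earlier compounds showed only dimethylamino and the methoxy and ethoxy chains here, whereas compound 4 shows that methanesulfonamido, with its 5 heavy atoms and 1 hydrogen-bond donor, gives no sign of higher toxicity in this test, though the size of the step stays unknown because the reading stops at a limit: the limit of > 25000 nM in this assay, at which 1 of the 4 values shown sits.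

Going by these compounds, it stays open how far compound 4 lies past its limit, and so whether its steps leave the scatter at all. Also open, on these data alone, is how a primary amine, a carboxylic acid or a longer chain in place of methanesulfonamido would read in this assay.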